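Urea series: extending the para substituent on the aniline ring

This account rests on a few compounds, and the source may have more. Where it says the series, first, only, none or still open, it means among the compounds named here.

Compound 2 `CC(C)(C)c1ccccc1Oc1ncccc1NC(=O)Nc1ccc(N2CCCCC2)cc1` is the reference point. In an assay on isolated protein for binding affinity to P2Y purinoceptor 1 (Homo sapiens) (on this read-out lower numbers stand for stronger inhibition and higher numbers for weaker inhibition), compound 2 gives 11 nM. Compound 3 `CC(C)(C)c1ccccc1Oc1ncccc1NC(=O)Nc1ccc(OCC2CCN(Cc3ccccc3)CC2)cc1F` gives 11 nM in this assay, a number level with that of compound 2 at the digits shown, and the two together stand at the low end of the three measured. Compound 1 `CC(C)(C)c1ccccc1Oc1ncccc1NC(=O)Nc1ccc(C2(CO)CC2)cc1` gives 176 nM, the highest number of the set.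

Among the compounds with values here, the only single-place step measured is a 16-fold lower number from compound 1 to compound 2 (1.20 log units; beyond the scatter); that step exchanges a different group and says little directly about what follows.

Compound 4 `CC(C)CN1CCC(COc2ccc(NC(=O)Nc3cccnc3Oc3ccccc3C(C)(C)C)cc2)CC1` differs from compound 2 by (1-isobutylpiperidin-4-yl)methoxy in place of piperidin-1-yl on an aromatic carbon. The change keeps a six-membered ring with one hetero atom but moves it out on a methoxy linker and adds an isobutyl on the ring nitrogen. Within the data shown here, no measured step covers this exact exchange. What can be drawn on is compound 3, which carries a related piperidinylmethoxy group on the same ring and gives the same number in this assay as compound 2; its extra ring fluorine and benzyl group are not isolated in any step.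

On that basis no step beyond the scatter is expected for a 1.1-fold higher number from compound 2 to compound 4 (0.04 log units; within the scatter). Compound 4 is estimated at 12 nM in this assay, with a plausible range from 4 nM to 40 nM.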

Compound 4, inhibition constant in the P2Y purinoceptor 1 assay: 87 nM
Compound 4: the middle estimate sits 7.3-fold (0.86 log units) below what was measured; measured number above the stated range.
By their numbers in the P2Y purinoceptor 1 assay, from the lowest: compounds 2 and 3 (each within the scatter of the next); then compound 4; then compound 1.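

In the P2Y purinoceptor 1 assay, this position, para to a large group, does not treat the two six-membered rings alike: (1-isobutylpiperidin-4-yl)methoxy does not hold the level of piperidin-1-yl (a 7.9-fold higher number from compound 2 to compound 4 (0.90 log units; beyond the scatter)), yet it still reads better than 1-(hydroxymethyl)cyclopropyl (a 2.0-fold lower number from compound 1 to compound 4 (0.31 log units; beyond the scatter)). The place therefore responds to what is carried out on the linker, and a ring with one hetero atom is not enough on its own to keep the low number of compound 2. The same exchange also shifts a physicochemical assay for lipophilicity, read by HPLC (a higher number here means a more lipophilic compound, a lower number a more polar compound), where compound 2 gives 5.5 and compound 4 gives 4.5, with compound 4 the more polar of the pair: the measured partition coefficient of compound 2, 5.5, and of compound 4, 4.5, a number 1.00 log units lower (beyond the scatter)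

The compounds shown do not separate the methoxy linker from the isobutyl on the ring nitrogen, and the ring fluorine and benzyl group of compound 3 remain unseparated as well, so the source of the higher number of compound 4 stays unassigned. Also open, on these data alone, is how the same linker would read with a methyl on the ring nitrogen, or with a morpholine in place of the piperidine.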